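The source may hold more compounds than are shown below. What is called first, only, known or untested is meant among the compounds shown, and "the series" means these compounds.

Working notes on the series. Compound 1 `Cn1ccnc1[C@@H](CC(=O)O)c1ccc(OCc2cccc(-c3ccccc3S(C)(=O)=O)c2)cc1` gives "not determined" (no result reported) in an assay on CHO cells for agonist activity at Free fatty acid receptor 1 (Homo sapiens), read by luminescence, with a stated time of 20 s, in the presence of a further agent that is not named here (a lower number here means that less compound is needed, a higher number that more compound is needed for the effect), that is, no result is reported for it. Compound 2 `Cc1cc(Cl)ccc1-c1cccc(COc2ccc([C@H](CC(=O)O)c3nccn3C)cc2)c1C` gives 23000 nM in this assay. Compound 3 `Cc1c(Cl)cccc1-c1cccc(COc2ccc([C@H](CC(=O)O)c3nccn3C)cc2)c1` gives 22000 nM in this assay; set against compound 2, the two numbers lie within the usual scatter of each other, so compound 3 stands at the same level as compound 2 rather than apart from it, and no order between the two is claimed. Compound 4 `Cc1ccc(F)cc1-c1cccc(COc2ccc([C@H](CC(=O)O)c3nccn3C)cc2)c1` is the next entry and has not yet been measured. It differs from compound 3 by 5-fluoro-2-methylphenyl in place of 3-chloro-2-methylphenyl on an aromatic carbon. Within the data shown here, no step between two measured compounds that differ in a single place is available to calibrate this change, so the expectation rests on the structural change alone. The step from compound 3 to compound 4 is expected to be a 1.1-fold higher number from compound 3 to compound 4 (0.06 log units; within the scatter), which is not beyond the usual scatter. In this assay compound 4 is accordingly estimated at 25000 nM, with a plausible range from 8000 nM to 80000 nM.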

Compound 4, half-maximal effective concentration: 42000 nM
Compound 4: middle estimate off by 1.7-fold (0.23 log units), on the low side, and the stated range covers the measured number.
By their numbers in this assay, from the lowest: compounds 3, 2 and 4 (each within the scatter of the next).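

In this assay, 5-fluoro-2-methylphenyl in place of 3-chloro-2-methylphenyl gives a 1.9-fold higher number from compound 3 to compound 4 (0.28 log units; within the scatter), so neither compound is set apart from the other. Among these compounds, this is the first single-place step, and it shows that this exchange, between two groups with the same heavy-atom count and no hydrogen-bond donors or acceptors, does not move the number beyond the scatter at this aromatic carbon, meta to a large group. No measurement bearing on the reason for this result is available, so the step stands as a description only.

As far as these compounds go, what remains open is whether any group at this place can shift the number beyond the scatter. A phenyl ring bearing an amine or a carboxylic acid is not among the compounds shown, so the effect of such a group here is unknown.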